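Aryl ether series: cytotoxicity notes on compounds 1 to 4

This account rests on a few compounds, and the source may have more. Where it says the series, first, only, none or still open, it means among the compounds named here.

Measured so far:
- compound 1, `Cc1cccnc1OC(c1ccc(C(F)(F)F)cc1)C1CCN(C(C)CCNC(=O)c2c(Cl)cncc2Cl)CC1`: 33000 nM
- compound 2, `CC(CCNC(=O)c1c(Cl)cncc1Cl)N1CCC(C(Oc2cccc(Cl)n2)c2ccc(S(C)(=O)=O)cc2)CC1`: > 29500 nM
- compound 3, `CCO/N=C(/c1ccc(Br)cc1)C1CCN(C(C)CCNC(=O)c2c(C)cc[n+]([O-])c2C)CC1`: > 177000 nM

Among the compounds with values here, in an ADME assay on PBMC cells (Homo sapiens) for cytotoxicity (on this read-out lower numbers stand for higher toxicity in this test and higher numbers for lower toxicity in this test), compound 1 gives 33000 nM and is the only compound with a number rather than a limit. For compound 2 the result of > 29500 nM is a limit of the test, not a number (the limit of > 29500 nM in this assay, at which 1 of the 3 values shown sits). For compound 3 the result of > 177000 nM is likewise a limit of the test (the limit of > 177000 nM in this assay, at which 1 of the 3 values shown sits). Compound 1 therefore stands as the sole fixed point; no comparison of its number with the two limits can be drawn beyond what each shows.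

Compound 4, `CC(CCNC(=O)c1c(Cl)cncc1Cl)N1CCC(C(Oc2ccccc2C#N)c2ccc(C(F)(F)F)cc2)CC1`, is not yet measured. It differs from compound 1 in one place: 2-cyanophenyl in place of 3-methylpyridin-2-yl on an oxygen on a saturated carbon. The amide part and the central saturated ring are shared, with only the aryl ether group exchanged.

Within the data shown here, no measured pair with a single change is available, so the size of the step rests on the overall picture of low toxicity in this set. No step beyond the usual scatter of the test is expected. Compound 4 is expected to give 35000 nM, with a range of 15000 nM to 80000 nM. The expected step of a 1.1-fold higher number from compound 1 to compound 4 (0.03 log units; within the scatter) is estimated to sit within the scatter of repeated measurements.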

Compound 4, half-maximal cytotoxic concentration: 17000 nM
Beside the measured number, compound 4's estimate is 2.1-fold (0.31 log units) above it; low and high end bracket the measured number.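

In this assay, the exchange on an oxygen on a saturated carbon gives the only single-place step in the series shown: a 1.9-fold lower number from compound 1 to compound 4 (0.29 log units; within the scatter). At this position, a six-membered aromatic ring of carbon only bearing a nitrile therefore reads the same, within the scatter, as 3-methylpyridin-2-yl with its ring hetero atom. No measurement shown bears on this result.

As far as these compounds go, what a carboxylic acid or a primary amine on the aryl ring would give in this assay remains open, as does whether the step holds with a group other than trifluoromethyl on the second aromatic ring. Compound 2 and compound 3 stand only as limits and differ from compound 1 in more than one place, so they add no comparison.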